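Replacing isopentyl in compound 3

The source may report more compounds than this note shows. Statements on the series, on what has been measured and on what is new or still open speak of the compounds shown alone.

Measured so far in a physicochemical assay for lipophilicity; on this read-out higher numbers stand for higher lipophilicity and lower numbers for lower lipophilicity
Compound 1 `COC(=O)/C=C(C)/C=C/CC(C)CCCC(C)(C)OC` gives 5
Compound 2 `CCCOC(=O)/C=C(C)/C=C/CC(C)CCCC(C)(C)OC` gives 6.08
Compound 3 `COC(C)(C)CCCC(C)C/C=C/C(C)=C/C(=O)OCCC(C)C` gives 7.03

Compound 3 stands highest of the three, at 7.03 on this scale. Compound 4 `C=CC(C)OC(=O)/C=C(C)/C=C/CC(C)CCCC(C)(C)OC` carries 1-methylprop-2-en-1-yl in place of isopentyl on an oxygen next to a carbonyl group and keeps the rest of the structure unchanged.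

Among the measured compounds shown here, three measured steps concern the group on that oxygen. The step of a number 1.08 log units higher from compound 1 to compound 2 (beyond the scatter) is large, the step of a number 2.03 log units higher from compound 1 to compound 3 (beyond the scatter) is also large, and the step of a number 0.95 log units higher from compound 2 to compound 3 (beyond the scatter) is modest. All three run upward as that group grows. None of compounds 1, 2 and 3 has a double bond in that group, so these steps guide the expectation only in part.

A modest fall beyond the scatter is expected in this assay, an estimated a number 0.83 log units lower from compound 3 to compound 4 (beyond the scatter) in all. Compound 4 is estimated at 6.2, with 5.75 to 6.65 as its expected range.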

Compound 4, partition coefficient: 5.94
Beside the measured number, compound 4's estimate is 0.26 log units above it; the range from low to high includes it.
By their numbers in this assay, from the lowest: compound 1; then compounds 4 and 2 (each within the scatter of the next); then compound 3.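

In this assay, 1-methylprop-2-en-1-yl in place of isopentyl on an oxygen next to a carbonyl group gives a number 1.09 log units lower from compound 3 to compound 4 (beyond the scatter) and is large, so a change at this position can also run downward, which none of the three earlier steps did. The same group in place of propyl gives a number 0.14 log units lower from compound 2 to compound 4 (within the scatter) and leaves the two groups indistinguishable on this read-out, while in place of methyl it gives a number 0.94 log units higher from compound 1 to compound 4 (beyond the scatter) and stays modest. Nothing in the data explains these differences.

Whether the double bond or the branching of 1-methylprop-2-en-1-yl matters more stays open, as sec-butyl, its saturated counterpart, is not among the compounds shown. From the compounds shown here alone, how a benzyl or a 2-hydroxyethyl group on that oxygen would read in this assay also remains open.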